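Swapping an Amino Group for Two Nitro Groups

The source may hold more compounds than are shown below. What is called first, only, known or untested is meant among the compounds shown, and "the series" means these compounds.

Measured compounds:
Compound 1 `Nc1ccc(Oc2ccccc2-c2ccc(S(=O)(=O)NCCNC(=O)Nc3ccc(Cl)cc3)s2)cc1` gives in a functional assay on HL-60 cells (Homo sapiens) for inhibition, read by CCK-8 assay, with a stated time of 48 h (a lower number here means a stronger inhibitor, a higher number a weaker inhibitor), only a limit, > 50000 nM.
Compound 2 `Cc1cc(C)cc(NC(=O)NCCNS(=O)(=O)c2ccc(-c3ccccc3OCc3ccccc3)s2)c1` gives in this assay a value of 2200 nM.
Compound 3 `COc1ccc(Oc2ccc(C(C)C)cc2-c2ccsc2S(=O)(=O)NCCNC(=O)Nc2cc(Cl)cc(Cl)c2)cc1OC` gives in this assay a value of 6500 nM.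

Compound 1 stands at the edge of what the measurement can report: the limit of > 50000 nM in this assay, at which 1 of the 3 values shown sits. On these data alone, a limit is not a number, so where compound 1 truly sits on the scale remains open; all that is known is that it is a weak inhibitor in this assay. Compounds 2 and 3, which share the core but carry other groups, do give numbers and are the only anchors for how strong compounds of this family can be.

Compound 4 `O=C(NCCNS(=O)(=O)c1ccc(-c2ccccc2Oc2ccc([N+](=O)[O-])c([N+](=O)[O-])c2)s1)Nc1ccc(Cl)cc1` differs from compound 1 in one place: 3,4-dinitrophenyl in place of 4-aminophenyl on an oxygen on an aromatic ring. Going by the values given here, no measured pair here shows what this change does, so its size in this assay can only be guessed. The step of an at least 1.6-fold lower number from compound 1 to compound 4 (0.22 log units; that floor lies within the scatter) is expected to be a modest gain, because compound 1 sits at the limit of > 50000 nM in this assay, at which 1 of the 3 values shown sits, and can hardly become weaker on the reported scale. Compound 4 is therefore expected to give about 30000 nM, most likely between 5000 nM and 100000 nM, with a real chance that it too is reported only as a limit.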

Compound 4, half-maximal inhibitory concentration: 8100 nM
For compound 4 the middle estimate is 3.7-fold (0.57 log units) above the measured one; the measured number falls inside the stated range.
By their numbers in this assay, from the lowest: compound 2; then compounds 3 and 4 (each within the scatter of the next). At a limit, above all of these: compound 1.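

In this assay, putting 3,4-dinitrophenyl in place of 4-aminophenyl on an oxygen on an aromatic ring gives an at least 6.1-fold lower number from compound 1 to compound 4 (0.79 log units; beyond the scatter), so the activity of this family does respond to what is placed here. On these data alone, the true size of this step stays unknown, because compound 1 is reported only as a limit: the limit of > 50000 nM in this assay, at which 1 of the 4 values shown sits. The printed step is therefore a floor, and the real gain could be the same or larger, but not smaller.

This single pair changes two things at once, removing the amino group and adding two nitro groups, so it cannot show whether the gain comes from losing the one or gaining the other. Whether a single nitro group, a methoxy group or a carboxylic acid on that phenyl ring would bring a compound close to compound 4 or leave it close to compound 1 remains open among the compounds shown.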